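A few compounds are considered here, and "the series" means these few. Any claim that something is new, unique, unknown or untested is made for them only; others in the source may bear on it.

Measured compounds:
compound 1 `COc1cc(C)cc(-c2c(-c3ccnc(-c4ccc(C(C)=O)cc4)c3)cnn2CC#N)c1` — > 100000 nM
compound 2 `COc1cc(C)cc(-c2nn(CC#N)cc2-c2ccc(-c3cccc(C(C)=O)c3)nc2)c1` — 6770 nM
compound 3 `Cc1cc(O)cc(-c2nn(CC#N)cc2-c2ccnc(-c3ccc(Oc4ccccc4)cc3)c2)c1` — 3390 nM

All three were tested in a functional assay on HCC 2998 cells (Homo sapiens) for inhibition, read by sulforhodamine B assay, with a stated time of 48 h; a lower number here means a stronger inhibitor of growth, a higher number a weaker inhibitor of growth. The entry for compound 1 is a limit of this assay and not a number, as the limit of > 100000 nM in this assay, at which 1 of the 3 values shown sits, records. Of the two numbers, compound 3 shows the smallest, yet compound 2 lies within the usual scatter of it, so the two cannot be told apart on these data. Within the data shown here, no pair of measured compounds differs in a single place, so no measured step is available to guide the next change.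

Compound 4 `Cc1cc(O)cc(-c2nn(CC#N)cc2-c2ccnc(-c3ccc(N(C)C)cc3)c2)c1` differs from compound 3 by dimethylamino in place of phenoxy on an aromatic carbon. With nothing measured on this kind of exchange, the step is expected to stay within the scatter, in no particular direction: the estimated step is a 1.2-fold higher number from compound 3 to compound 4 (0.07 log units; within the scatter). Compound 4 is accordingly expected to give about 4000 nM in this assay, with the estimate spanning from 1500 nM to 12000 nM.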

Compound 4, concentration for total growth inhibition: 13200 nM
Compound 4: the middle estimate sits 3.3-fold (0.52 log units) below what was measured; measured number above the stated range.
By their numbers in this assay, from the lowest: compounds 3, 2 and 4 (each within the scatter of the next, the first and the last beyond it). At a limit, above all of these: compound 1.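

In this assay, among these compounds, the exchange of phenoxy for dimethylamino gives a 3.9-fold higher number from compound 3 to compound 4 (0.59 log units; beyond the scatter) and is the first single-place step in the set. It shows that at this position, on an aromatic carbon para to a large group, the two groups are not interchangeable, and that of this pair the compound carrying phenoxy is the stronger inhibitor of growth. The two groups have the same count of hydrogen-bond donors and acceptors but differ in ring and in heavy atoms, and nothing measured here gives a cause for the step.

From the compounds shown here alone, whether a morpholine ring, a benzyloxy group or a plain methoxy group at this place would give a number nearer that of compound 3 or of compound 4 stays open. Going by these compounds, it is also open whether the same exchange would give a similar step on the core of compound 2.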